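The source may hold more compounds than are shown below. What is called first, only, known or untested is meant among the compounds shown, and "the series" means these compounds.

Measured compounds:
compound 1 `Cc1cc(Nc2cc(-c3ccccc3)[nH]n2)n2nc(SCc3ccc([N+](=O)[O-])cc3)nc2n1`, 5060 nM
compound 2 `Cc1cc(Nc2cc(-c3ccccc3)[nH]n2)n2nc(SCCc3ccccc3)nc2n1`, 2700 nM
compound 3 `Cc1cc(Nc2cc(-c3ccccc3)[nH]n2)n2nc(SCc3cccc4ccccc34)nc2n1`, 7560 nM

All three share one core and differ only in the group on the saturated chain carbon bound to the sulfur. In a functional assay on MCF7 cells (Homo sapiens) for inhibition, read by MTT assay, with a stated time of 72 h (on this read-out lower numbers stand for stronger inhibition and higher numbers for weaker inhibition), compound 3 gives the highest of the three numbers; the two steps leading to it are a 1.5-fold higher number from compound 1 to compound 3 (0.17 log units; within the scatter) and a 2.8-fold higher number from compound 2 to compound 3 (0.45 log units; beyond the scatter), the latter modest but beyond the scatter.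

Compound 4 `Cc1cc(Nc2cc(-c3ccccc3)[nH]n2)n2nc(SCc3ccc(Br)cc3)nc2n1` is not yet measured. It differs from compound 3 by 4-bromophenyl in place of naphthalen-1-yl on a saturated chain carbon bound to a sulfur. Within the data shown here, two measured steps bear on this: the step from compound 2 to compound 3 shows that bringing in naphthalen-1-yl costs a modest amount, and the step from compound 1 to compound 3 shows that a change from 4-nitrophenyl to naphthalen-1-yl stays within the scatter. Removing naphthalen-1-yl again in favour of 4-bromophenyl is therefore expected to give a small step toward a lower number in this assay, at most modest in size, and possibly none beyond the scatter. Compound 4 is expected to come in near the value of compound 1, with a 1.5-fold lower number from compound 3 to compound 4 (0.18 log units; within the scatter), estimated at 5000 nM within 2500 nM to 10000 nM.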

Compound 4, half-maximal inhibitory concentration: 2720 nM
Estimate against measurement, compound 4: 1.8-fold (0.26 log units) above; low and high end bracket the measured number.
By their numbers in this assay, from the lowest: compounds 2, 4, 1 and 3 (each within the scatter of the next, the first and the last beyond it).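

In this assay, the place on a saturated chain carbon bound to a sulfur now gives a second step beyond the scatter (a 2.8-fold lower number from compound 3 to compound 4 (0.44 log units; beyond the scatter)), and compound 3, with its naphthalen-1-yl group, stands apart from both compound 2 and compound 4, though not from compound 1. 4-Bromophenyl and benzyl are not told apart here (a 1.0-fold higher number from compound 2 to compound 4 (0.00 log units; within the scatter)), and neither are bromo and nitro on an aromatic carbon (a 1.9-fold lower number from compound 1 to compound 4 (0.27 log units; within the scatter)). Nothing available accounts for these steps.

Still open, on these data alone, is whether a carboxylic acid or an amine on the aromatic ring at this place would give a number outside those seen so far. As far as these compounds go, a longer chain on the sulfur and any change to the shared core also remain open.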